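From piperidin-1-yl to pyrrolidin-1-yl: what to expect

The source may hold more compounds than are shown below. What is called first, only, known or untested is meant among the compounds shown, and "the series" means these compounds.

Two related compounds have been measured so far. In an ADME assay on SH-SY5Y cells (Homo sapiens) for cytotoxicity, read by MTT assay, with a stated time of 48 h (a higher number here means that more compound is needed for the effect, a lower number that less compound is needed), compound 1 (`CN(C)Cc1cn(-c2ccccc2C(=O)NCCCCCCCn2cc(-c3cccnc3)nn2)nn1`) gives 285 nM.

Compound 2 (`O=C(NCCCCCCCn1cc(-c2cccnc2)nn1)c1ccccc1-n1cc(CN2CCCCC2)nn1`) gives > 500 nM, which is a limit of the assay and not a number. Its position is therefore known only as the limit of > 500 nM in this assay, at which 1 of the 2 values shown sits.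

Compound 3 (`O=C(NCCCCCCCn1cc(-c2cccnc2)nn1)c1ccccc1-n1cc(CN2CCCC2)nn1`) has not yet been measured. It carries pyrrolidin-1-yl in place of piperidin-1-yl on a saturated chain carbon bound to an aromatic carbon.

Going by the values given here, only one measured step bears on this change. Putting piperidin-1-yl in place of dimethylamino at that same carbon gave an at least 1.7-fold higher number from compound 1 to compound 2 (0.24 log units; that floor lies within the scatter). That step is a floor and does not clearly exceed the scatter, so it offers no firm direction for the new change. No step beyond the scatter is therefore expected in this assay, and compound 3 may also be reported only as a limit.

The estimated change is an at least 1.2-fold lower number from compound 2 to compound 3 (0.09 log units; that floor lies within the scatter). For compound 3, the expected value is 400 nM, with an estimated range from 170 nM to 900 nM.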

Compound 3, half-maximal effective concentration: > 10000 nM
Compound 3: no number, only a limit; the forecaster's own chance of this, stated with the estimate: 40%; middle value at least 25-fold (1.39 log units) away from the limit.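

The position of compound 3 is known only as a limit: the limit of > 10000 nM in this assay, at which 1 of the 3 values shown sits.

Going by these compounds alone, this limit gives the first step at this place that clearly exceeds the scatter: in this assay, replacing dimethylamino with pyrrolidin-1-yl on the saturated chain carbon bound to an aromatic carbon gives an at least 35-fold higher number from compound 1 to compound 3 (1.54 log units; beyond the scatter). The earlier step gave only a floor within the scatter, so the group at this carbon is now shown to be able to change the result by a large margin, even though it is the only part of the structure that differs between these two compounds.

The step between the two ring-bearing compounds cannot be read, as both compounds are reported only as limits, so the compounds shown do not tell whether pyrrolidin-1-yl and piperidin-1-yl differ here at all, or how far the true value of compound 3 lies past its limit. Also open, as far as these compounds go, is where a morpholin-4-yl group or a diethylamino group at the same carbon would fall in this assay, and whether either would give a number and not a limit.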